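The compounds below may be only part of what the source reports. "The series", "measured", "known", "first", "only" and "open" are said of these compounds alone.

In a functional assay on PC-3 cells (Homo sapiens) for cytotoxicity, read by MTT assay, with a stated time of 72 h (on this read-out lower numbers stand for stronger inhibition and higher numbers for weaker inhibition), three related compounds have been tested so far. Compound 1 (`O=C(N/N=C/c1ccc(F)cc1)Nc1cc2c(Nc3ccc(F)c(Cl)c3)ncnc2cc1O[C@H]1CCOC1`) is reported as "not active" (no number reported) with no number attached. Compound 2 (`O=C(N/N=C/c1ccc(O)c(Br)c1)Nc1cc2c(Nc3ccc(F)c(Cl)c3)ncnc2cc1O[C@H]1CCOC1`) gives 5230 nM and compound 3 (`COc1cc2ncnc(Nc3ccc(F)c(Cl)c3)c2cc1NC(=O)N/N=C/c1ccc(F)cc1`) gives 36500 nM as its reading. Compound 3 therefore holds the higher of the two numbers, which means weaker inhibition than compound 2, and the gap between them lies beyond the scatter of repeated measurements.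

Compound 4 (`COc1cc2ncnc(Nc3ccc(F)c(Cl)c3)c2cc1NC(=O)N/N=C/c1ccc(F)cc1Cl`) has not been measured. It differs from compound 3 in one place (chloro in place of hydrogen on an aromatic carbon): chloro in place of hydrogen on an aromatic carbon, ortho to a large group and meta to a fluoro group, so that 4-fluorophenyl becomes 2-chloro-4-fluorophenyl. Among the compounds with values here, no two measured compounds here differ in one place only, so nothing shows directly what such a change does. The best anchor is compound 3 at 36500 nM as the closest measured relative, and the reading is expected to stay in that same range. The estimated change is a 1.2-fold lower number from compound 3 to compound 4 (0.09 log units; within the scatter) and is expected to remain within the scatter, with no firm direction. For compound 4 the estimated value is 30000 nM with an expected range from 9000 nM to 90000 nM in this assay as well.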

Compound 4, half-maximal inhibitory concentration: 25700 nM
Estimate against measurement, compound 4: 1.2-fold (0.07 log units) above, and the stated range covers the measured number.
By their numbers in this assay, from the lowest: compound 2; then compounds 4 and 3 (each within the scatter of the next).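

Within the data shown here, compounds 3 and 4 are the first pair here that differ in one place only, so the effect of a single change can finally be read directly. In this assay, placing chloro on the aromatic carbon ortho to a large group, which turns 4-fluorophenyl into 2-chloro-4-fluorophenyl, gives a 1.4-fold lower number from compound 3 to compound 4 (0.15 log units; within the scatter), so this one pair shows that the position can carry a chlorine atom with no change that can be told apart from the usual scatter of repeated measurements. No measurement is available that could explain this outcome at this position.

Going by these compounds, a single substituent on a single pair says little about the position as a whole, so it remains open whether a different group at this carbon, such as an amine or a carboxylic acid, would shift the number beyond the scatter. On these data alone, it is also open whether the same chloro change would behave alike on the core of compound 1, which carries a different side group and has no number to compare against.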